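Swapping a ring oxygen out: compound 2 to compound 4

This account rests on a few compounds, and the source may have more. Where it says the series, first, only, none or still open, it means among the compounds named here.

Measured so far:
Compound 1, `Cc1nnc(N2CCC(C(=O)N3N=CC[C@H]3c3cc(F)cc(F)c3)CC2)o1`, in a physicochemical assay for lipophilicity, read by HPLC, measured as chromatographic lipophilicity, at pH 7.4 (a lower number here means a more polar compound, a higher number a more lipophilic compound), compound 1 gives 3.6.
Compound 2, `O=C(C1CCOCC1)N1N=CCC1c1ccccc1`, in this assay compound 2 gives 3.1.
Compound 3, `CC(C)(C)C(=O)N1N=CCC1c1ccncc1`, in this assay compound 3 gives 3.2.

Among these three numbers compound 2 sits at the low end. Its value and that of compound 3 lie within the usual scatter of one another, so nothing separates them. Compound 1 stands higher than compound 2 by a margin beyond the scatter.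

Compound 4, `O=C(C1CCCC1)N1N=CCC1c1ccccc1`, is not yet measured. It differs from compound 2 in one place: cyclopentyl in place of oxan-4-yl on a carbonyl carbon. What leaves carries one hydrogen-bond acceptor and one hetero atom in its ring; what enters is a five-membered ring of carbon only, with no acceptor.

For the measured compounds named here, no measured pair in this set isolates such a change, so the size of the step in this assay is an expectation only. Compound 4 is expected to come out more lipophilic than compound 2, with a step of a number 1.00 log units higher from compound 2 to compound 4 (beyond the scatter), well beyond the scatter. The estimated value for compound 4 is 4.1, expected to fall between 3.6 and 4.6.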

Compound 4, distribution coefficient: 5.4
Beside the measured number, compound 4's estimate is 1.30 log units below it; the measured number lies above the stated range.
By their numbers in this assay, from the lowest: compounds 2 and 3 (each within the scatter of the next); then compound 1; then compound 4.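

In this assay, for the compounds shown here, cyclopentyl in place of oxan-4-yl on a carbonyl carbon gives a number 2.30 log units higher from compound 2 to compound 4 (beyond the scatter), the first step in this set that can be read from a change in one place. It shows that, with the rest of compound 2 left as it stands, this one position can carry a large shift in the reading, which compounds 1, 2 and 3 could not show, since they differ from one another in more than one place. Nothing measured here says why the step has this size.

Two changes travel together in this step, the loss of the ring oxygen and the change in ring size, and a cyclohexyl group on the same carbonyl carbon would be needed to pull them apart. As far as these compounds go, whether a step of like size appears on the core of compound 3 also stays open.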